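Swapping fluorine position across two related ring cores

A few compounds are considered here, and "the series" means these few. Any claim that something is new, unique, unknown or untested is made for them only; others in the source may bear on it.

Compound 1 `COc1ccc(-n2nc(Sc3ccc(Cl)cc3)cc(CC[C@@H](C)NC(=O)[C@H]3CCNC[C@@H]3c3ccc(F)cc3)c2=O)cc1`: 66 nM
Compound 2 `COc1ccc(-n2nc(Sc3ccc(Cl)cc3)cc(CC[C@@H](C)NC(=O)[C@H]3CCNC[C@@H]3c3ccccc3F)c2=O)cc1`: 100 nM
Compound 3 `COc1ccc(-n2nc(Sc3ccc(Cl)cc3)cc(CC[C@@H](C)NC(=O)[C@H]3CNC[C@@H]3c3ccccc3F)c2=O)cc1`: 160 nM

These three compounds were tested in an assay on CHO cells for binding affinity to Melanocortin receptor 4 (Homo sapiens); a higher number here means a weaker inhibitor, a lower number a stronger inhibitor. Compound 1 and compound 2 share one core; the change between them is 4-fluorophenyl in place of 2-fluorophenyl on a saturated ring carbon, and it gave a 1.5-fold lower number from compound 2 to compound 1 (0.18 log units; within the scatter). Compound 3 carries a different core; how its core differs from that of compound 2 is not broken down here, and in this assay compound 3 gives 160 nM.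

Compound 4 `COc1ccc(-n2nc(Sc3ccc(Cl)cc3)cc(CC[C@@H](C)NC(=O)[C@H]3CNC[C@@H]3c3ccc(F)cc3)c2=O)cc1` has not yet been measured. It differs from compound 3 by 4-fluorophenyl in place of 2-fluorophenyl on a saturated ring carbon. Among the measured compounds shown here, this is the same kind of change as the one from compound 2 to compound 1, though here the place is on a five-membered non-aromatic ring with 1 nitrogen rather than a six-membered one. Resting on the step of a 1.5-fold lower number from compound 2 to compound 1 (0.18 log units; within the scatter), the expected step is a 1.5-fold lower number from compound 3 to compound 4 (0.16 log units; within the scatter). Compound 4 is therefore estimated at 110 nM, likely between 50 nM and 250 nM.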

Compound 4, half-maximal inhibitory concentration: 70 nM
The estimate for compound 4 lay 1.6-fold (0.20 log units) above the measured number; the range from low to high includes it.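

In this assay, replacing 2-fluorophenyl with 4-fluorophenyl on the second core gave a 2.3-fold lower number from compound 3 to compound 4 (0.36 log units; beyond the scatter). The two steps point the same way and the gap between them stays within normal measurement scatter, so the change carried over from one core to the other: the same change on two cores in this assay, a 1.5-fold lower number (0.18 log units; within the scatter) from compound 2 to compound 1 and a 2.3-fold lower number (0.36 log units; beyond the scatter) from compound 3 to compound 4, 1.5-fold (0.18 log units) apart, within the scatter of two such steps. Among the compounds shown here, this rests on only two pairs of compounds, so it does not show that the step truly differs in size between the cores, or that it would hold on any further core.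

Still open, as far as these compounds go, is whether the same step would appear with chlorine or a methoxy group on the phenyl ring in place of fluorine. From the compounds shown here alone, how a methyl group on the ring nitrogen would read in this assay also remains open.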